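Swapping one side chain on a carbonyl carbon

The source may report more compounds than this note shows. Statements on the series, on what has been measured and on what is new or still open speak of the compounds shown alone.

Results in an ADME assay on microsomes from liver (Homo sapiens) for metabolic stability, with a stated time of 0.5 h (on this read-out higher numbers stand for a more stable compound and lower numbers for a less stable compound), so far:
- Compound 1 `Cn1c(=O)c(S(C)(=O)=O)c(CCc2ccccc2)c2cc(OCC(=O)NCc3ccc(Cl)c(Cl)c3)ccc21` - "not determined" (no result reported)
- Compound 2 `CS(=O)(=O)c1c(CCc2ccccc2)c2cc(OCC(=O)NCC3CC3)ccc2[nH]c1=O` - "not determined" (no result reported)
- Compound 3 `CC(C)(NC(=O)NCc1ccc2[nH]c(=O)c(-c3nccs3)c(CCc3ccccc3)c2c1)c1ccccc1` - 40%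

Only compound 3 carries a number, 40%, so it stands alone, with no measured neighbour to set it against. The next compound is compound 4 `O=C(CCc1ccccc1)NCc1ccc2[nH]c(=O)c(-c3nccs3)c(CCc3ccccc3)c2c1`. The change from compound 3 is phenethyl in place of (1-methyl-1-phenylethyl)amino on a carbonyl carbon, with phenethyl in place of (1-methyl-1-phenylethyl)amino on a carbonyl carbon. Within the data shown here, no measured step shows what such a swap does. The expected change a number 7 percentage points lower from compound 3 to compound 4 (within the scatter) is therefore small, slightly downward and within the usual scatter of this assay. Compound 4 is expected at an estimated 33% (range 12% to 58%) once measured.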

Compound 4, percent of the compound remaining: 3%
Compound 4: middle estimate off by 30 percentage points, on the high side; measured number below the stated range.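

In this assay, among these compounds, the first measured step in this set falls on this carbonyl carbon: phenethyl in place of (1-methyl-1-phenylethyl)amino gives a number 37 percentage points lower from compound 3 to compound 4 (beyond the scatter) and shows that stability here depends strongly on this side chain. The group that leaves carries one hydrogen-bond donor, and the group that enters carries none. Nothing available accounts for the drop.

The compounds shown do not separate the part played by the amino nitrogen from that of the two methyl groups. Going by these compounds, how a morpholine or a benzylamino group on this carbonyl carbon would read also remains open.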